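The compounds below may be only part of what the source reports. "The series", "measured", "known", "first", "only" and "open" are said of these compounds alone.

Working notes on the amide series.

Compound 3 `O=C(Nc1nc(-c2ccccc2)nc2c1nnn2Cc1ccccc1)c1ccc(C(F)(F)F)cc1` gives 4210 nM in an assay on CHO cells for displacement of a labelled ligand from adenosine receptor A3 (Homo sapiens), read by scintillation counting (a lower number here means a stronger inhibitor, a higher number a weaker inhibitor), the highest number of the three measured; compound 2 `O=C(Nc1nc(-c2ccccc2)nc2c1nnn2Cc1ccccc1)c1ccoc1` gives 1640 nM and compound 1 `Nc1ccc(C(=O)Nc2nc(-c3ccccc3)nc3c2nnn3Cc2ccccc2)cc1` gives 926 nM. The unmeasured compound 4 `O=C(Nc1nc(-c2ccccc2)nc2c1nnn2Cc1ccccc1)c1ccccc1F` differs from compound 3 by 2-fluorophenyl in place of 4-(trifluoromethyl)phenyl on a carbonyl carbon. Going by the values given here, no measured step covers this exact change. The nearest comparisons are a 2.6-fold higher number from compound 2 to compound 3 (0.41 log units; beyond the scatter) and a 4.5-fold higher number from compound 1 to compound 3 (0.66 log units; beyond the scatter), both modest and both running toward compound 3, showing the group on the carbonyl carbon moves this assay by modest amounts. Among the compounds with values here, a modest move back toward the other two compounds is therefore expected, a 2.3-fold lower number from compound 3 to compound 4 (0.37 log units; beyond the scatter), though the direction rests on only two steps. Compound 4 is estimated at 1800 nM, with a range of 600 nM to 5500 nM.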

Compound 4, inhibition constant: 5300 nM
For compound 4 the middle estimate is 2.9-fold (0.47 log units) below the measured one; the measured number falls inside the stated range.
By their numbers in this assay, from the lowest: compounds 1 and 2 (each within the scatter of the next); then compounds 3 and 4 (each within the scatter of the next).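

In this assay, the change on the carbonyl carbon gives a 1.3-fold higher number from compound 3 to compound 4 (0.10 log units; within the scatter), so 2-fluorophenyl and 4-(trifluoromethyl)phenyl cannot be told apart here. The 2-fluorophenyl group also extends the spread at this position, with a 3.2-fold higher number from compound 2 to compound 4 (0.51 log units; beyond the scatter) and a 5.7-fold higher number from compound 1 to compound 4 (0.76 log units; beyond the scatter), though every step remains modest. Nothing at hand explains these differences.

The compounds shown leave open whether a carboxylic acid or a longer alkyl chain on the carbonyl carbon would fall with the two fluorinated groups or with compound 1.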